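The source may hold more compounds than are shown below. What is called first, only, known or untested is meant among the compounds shown, and "the series" means these compounds.

Notes on the series. Going by the values given here, compound 1 `Cc1ccc(Oc2c(/C=N\OCc3c(Cl)c(-c4ccc(F)cc4)nn3C)c(C)nn2C)cc1` and compound 2 `Cc1nn(C)c(Oc2ccc(Cl)cc2)c1/C=N\OCc1c(Cl)c(-c2ccc(Cl)cc2)nn1C` share one core and differ at two positions, so no single step between them is on record; only their two values can be compared. In a functional assay on HCT-116 cells (Homo sapiens) for antiproliferative activity, read by MTT assay, with a stated time of 72 h (on this read-out higher numbers stand for weaker inhibition and lower numbers for stronger inhibition), compound 1 gives 2910 nM. In this assay compound 2 gives 4670 nM. Compound 2 stands at the upper end of the two numbers shown, but its gap to compound 1 is within the usual scatter, so the two compounds are not separated on this assay.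

Compound 3 `Cc1ccc(Oc2c(/C=N\OCc3c(Cl)c(-c4ccc(Cl)cc4)nn3C)c(C)nn2C)cc1` differs from compound 2 in one place only: methyl in place of chloro on an aromatic carbon. Among the compounds with values here, no measured pair tells how this assay answers that exchange. With nothing to argue for a real shift, the step from compound 2 to compound 3 is expected to be none beyond the scatter, a 1.2-fold lower number from compound 2 to compound 3 (0.09 log units; within the scatter). Compound 3 is accordingly estimated at 3800 nM, in a range of 1600 nM to 9000 nM.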

Compound 3, half-maximal inhibitory concentration: 2850 nM
For compound 3 the middle estimate is 1.3-fold (0.12 log units) above the measured one; measured number inside the range.
By their numbers in this assay, from the lowest: compounds 3, 1 and 2 (each within the scatter of the next).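

In this assay, the exchange of 4-chlorophenoxy for 4-methylphenoxy now has a measured step, a 1.6-fold lower number from compound 2 to compound 3 (0.21 log units; within the scatter), so on this background the para position of that aromatic ring tolerates methyl in place of chloro without a separable change. The second exchange, chloro in place of fluoro on an aromatic carbon, gives a 1.0-fold lower number from compound 1 to compound 3 (0.01 log units; within the scatter), so neither single change separates the compounds, as the earlier two-position comparison could not show. Nothing measured here bears on why these exchanges leave the read-out within the scatter.

Each exchange rests on one pair and swaps only one small substituent for another. Going by these compounds, whether an amine, a carboxylic acid or a longer chain at either position would move the number beyond the scatter stays open.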